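Swapping the tert-butyl of compound 2 for a cyclohexyloxy

The source may report more compounds than this note shows. Statements on the series, on what has been measured and on what is new or still open speak of the compounds shown alone.

Measured compounds:
compound 1 `CCCc1ccc(COC(=O)N[C@H]2CNC2=O)cc1`: 52 nM
compound 2 `CC(C)(C)c1ccc(COC(=O)N[C@H]2CNC2=O)cc1`: 310 nM
compound 3 `O=C(N[C@H]1CNC1=O)OCc1ccc2c(c1)CCC2`: 130 nM

All three share the same core and were tested in an assay on HEK293 cells for inhibition of N-acylethanolamine-hydrolyzing acid amidase (Homo sapiens), read by fluorescence, with stated times of 10 min and 50 min; a lower number here means a stronger inhibitor, a higher number a weaker inhibitor. Compound 2 gives the highest number of the three: compound 3 lies 130 nM, and compound 1 lies lowest at 52 nM. Within the data shown here, the only step that differs in one place runs from compound 1 to compound 2, where the change a 6.0-fold higher number from compound 1 to compound 2 (0.78 log units; beyond the scatter) shows that replacing propyl by tert-butyl raised the number by a modest margin beyond the scatter.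

Compound 4 `O=C(N[C@H]1CNC1=O)OCc1ccc(OC2CCCCC2)cc1` is not yet measured. It differs from compound 2 by cyclohexyloxy in place of tert-butyl on an aromatic carbon. Among the measured compounds shown here, no measured pair covers a cyclohexyloxy group, so the only guidance is that compound 2, bearing tert-butyl, sits at the weak end of the series, while compounds 1 and 3 with other groups at that position sit lower. On that basis compound 4 is expected to fall below compound 2, with a step of roughly a 4.4-fold lower number from compound 2 to compound 4 (0.65 log units; beyond the scatter) in this assay, though the size is uncertain. The estimate for compound 4 is 70 nM, within a range from 20 nM to 250 nM.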

Compound 4, half-maximal inhibitory concentration: 2070 nM
Compound 4: the middle estimate sits 30-fold (1.47 log units) below what was measured, and the stated range ends below it.
By their numbers in this assay, from the lowest: compound 1; then compound 3; then compound 2; then compound 4.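

Among these compounds, measured in this assay this position, para to a large group, proves more demanding than the earlier compounds could show: cyclohexyloxy in place of tert-butyl gives a 6.7-fold higher number from compound 2 to compound 4 (0.82 log units; beyond the scatter) and thus takes the series past what had been its weak end. Set against propyl, the same group gives a 40-fold higher number from compound 1 to compound 4 (1.60 log units; beyond the scatter) and so the three groups compared here rank propyl, then tert-butyl, then cyclohexyloxy, from the lowest number to the highest. Nothing measured here gives a reason for this rise.

Cyclohexyloxy brings a ring and an oxygen together, so the compounds shown leave open which of them matters, a question that a cyclohexyl joined directly to the aromatic carbon or an open propoxy chain would address. From the compounds shown here alone, how an amine or a carboxylic acid would read at this position also remains open.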